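The compounds below may be only part of what the source reports. "The series", "measured", "known", "first", "only" and "open" are said of these compounds alone.

Compound 1 `CC(=O)c1ccc2c(c1)C(n1ccccc1=O)=CC(C)(C)O2`: 6.65
Compound 2 `CC1(C)C=C(n2ccccc2=O)c2cc(C(=O)c3ccc(O)cc3)ccc2O1`: 5.87

In a functional assay (trachea) with Rattus norvegicus as the target (a lower number here means a less potent compound, a higher number a more potent compound, by a factor of ten per unit of this negative logarithm), compound 1 holds the higher of the two numbers; the step of a number 0.78 log units lower from compound 1 to compound 2 (beyond the scatter) puts compound 2 clearly behind it. Compound 3 `CC1(C)C=C(n2ccccc2=O)c2cc(C(F)(F)F)ccc2O1` is the unmeasured partner of compound 1, and the change is trifluoromethyl in place of acetyl on an aromatic carbon. Among the compounds with values here, no measured step swaps the acetyl for another group in this position; the only known step alters the acetyl at its carbonyl carbon, and that cost potency. A modest loss is therefore expected, given as a number 0.35 log units lower from compound 1 to compound 3 (beyond the scatter). Compound 3 is estimated at 6.3, in the range 5.6 to 7.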

Compound 3, logarithm of the reciprocal of the active concentration, log(1/C): 7.37
Compound 3: the middle estimate sits 1.07 log units below what was measured; the whole stated range lies below it.
By their numbers in this assay, from the lowest: compound 2; then compound 1; then compound 3.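

At this aromatic carbon a carbonyl group is not needed for activity in this assay: trifluoromethyl in place of acetyl gives a number 0.72 log units higher from compound 1 to compound 3 (beyond the scatter) on the shared core. The same group in place of (4-hydroxyphenyl)carbonyl gives a number 1.50 log units higher from compound 2 to compound 3 (beyond the scatter) at this position, so of the three groups shown, the one without a carbonyl holds the top number. On these data alone, whether a nitrile, a halogen such as chlorine, or an amine at this carbon would match or pass trifluoromethyl remains open. Nothing available explains the gain.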